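This account rests on a few compounds, and the source may have more. Where it says the series, first, only, none or still open, it means among the compounds named here.

For the measured compounds named here, compound 2 `Cc1cc(=O)n(-c2cccc(F)c2)nc1C(=O)Nc1ccc(Oc2ncnc3ccsc23)c(F)c1` gives 9050 nM in a functional assay on MCF7 cells (Homo sapiens) for cytotoxicity, read by MTT assay, with a stated time of 72 h (on this read-out higher numbers stand for weaker inhibition and lower numbers for stronger inhibition), and stands highest of the two numbers known here; its only neighbour, compound 1 `Cc1cc(=O)n(-c2ccc(Br)cc2F)nc1C(=O)Nc1ccc(Oc2ncnc3ccsc23)c(F)c1` gives 1550 nM in this assay and the single measured step is a 5.8-fold higher number from compound 1 to compound 2 (0.77 log units; beyond the scatter) which went from a 4-bromo-2-fluorophenyl to a 3-fluorophenyl on the aromatic nitrogen. Compound 3 `Cc1cc(=O)n(-c2ccc(F)c(F)c2)nc1C(=O)Nc1ccc(Oc2ncnc3ccsc23)c(F)c1` differs from compound 2 by fluoro in place of hydrogen on an aromatic carbon and so carries a halogen again para to the large group. Because the step of a 5.8-fold higher number from compound 1 to compound 2 (0.77 log units; beyond the scatter) accompanied the loss of such a para halogen together with other changes, it bears on compound 3 only in part, and a step of smaller size toward a lower number is expected. Compound 3 is therefore estimated to give 3500 nM in this assay within a range from 1200 nM to 10000 nM with the expected step being a 2.6-fold lower number from compound 2 to compound 3 (0.41 log units; beyond the scatter).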

Compound 3, half-maximal inhibitory concentration: 6900 nM
Beside the measured number, compound 3's estimate is 2.0-fold (0.29 log units) below it, and the stated range covers the measured number.
By their numbers in this assay, from the lowest: compound 1; then compounds 3 and 2 (each within the scatter of the next).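

In this assay, fluoro in place of hydrogen on the aromatic carbon para to the large group gives a 1.3-fold lower number from compound 2 to compound 3 (0.12 log units; within the scatter), and this change does not separate the two compounds. A fluoro in that place does not by itself match the 4-bromo-2-fluorophenyl group: the 3,4-difluorophenyl group on the aromatic nitrogen still leaves a 4.5-fold higher number from compound 1 to compound 3 (0.65 log units; beyond the scatter). Nothing available here explains this result.

The 4-bromo-2-fluorophenyl and 3,4-difluorophenyl groups differ in more than one way, and the compounds shown do not tell whether the bromo or the position of the other fluoro goes with the lower number of compound 1. From the compounds shown here alone, how a chloro group, a methoxy group or an amine would read in the place of the new fluoro also remains open.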